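This account rests on a few compounds, and the source may have more. Where it says the series, first, only, none or still open, it means among the compounds named here.

Values so far in a functional assay on the whole organism (stomach) with Rattus norvegicus as the target (a higher number here means that more compound is needed for the effect, a lower number that less compound is needed), for this series:
- compound 1 `O=C(O)c1cc(NC(=O)c2cc(O)cc(O)c2)cc(C(=O)O)c1` gives 90.2 mg/kg
- compound 2 `O=C(O)c1cc(NC(=O)c2ccc(Cl)cc2)cc(C(=O)O)c1` gives 97.3 mg/kg
- compound 3 `O=C(Nc1ccccc1)c1cccc(-c2nn[nH]n2)c1` gives 38.1 mg/kg

Compound 2 stands level with compound 1 within the scatter, and its number lies beyond the scatter above that of compound 3. A higher number in this assay means more compound is needed, so compound 3 needs less than compound 2. Compound 3 does not share the core of compound 2 and gives little guidance here.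

The next compound is compound 4 `N#Cc1ccc(C(=O)Nc2cc(C(=O)O)cc(C(=O)O)c2)cc1`, which has cyano in place of chloro on an aromatic carbon of compound 2, para to a large group (cyano in place of chloro on an aromatic carbon). Among the measured compounds shown here, no measured pair differs in one place only, so the size of this change has no direct precedent. The nearest evidence is compound 1 (90.2 mg/kg), which shares the core of compound 2 and carries different substituents on the other ring, yet remains within the scatter of compound 2 (97.3 mg/kg). This is a single comparison. On that basis, no shift beyond the scatter is expected in either direction (a 1.1-fold lower number from compound 2 to compound 4 (0.03 log units; within the scatter)). Compound 4 is estimated at 90 mg/kg (expected range 45 mg/kg to 180 mg/kg).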

Compound 4, dose for 50% inhibition: 32.1 mg/kg
The estimate for compound 4 lay 2.8-fold (0.45 log units) above the measured number; the whole stated range lies above it.
By their numbers in this assay, from the lowest: compounds 4 and 3 (each within the scatter of the next); then compounds 1 and 2 (each within the scatter of the next).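

In this assay, among the compounds shown here, the aromatic carbon para to a large group is the first place where a single change can be read, and the position responds to it: cyano in place of chloro gives a 3.0-fold lower number from compound 2 to compound 4 (0.48 log units; beyond the scatter) on the shared core, a step that lies beyond the scatter. Less compound is therefore needed with cyano than with chloro at this place, which the earlier compounds could not show, as none of them formed a pair differing in one place only. No measurement at hand bears on why the number moves with this change.

Going by these compounds, the finding rests on a single pair, so it remains open whether the step is specific to cyano or whether other groups at this place, such as an amine, a methoxy group or trifluoromethyl, would give a similar number. On these data alone, it also remains open whether swapping chloro for cyano would give a step of similar size on a different core or at another place on this ring.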